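This account rests on a few compounds, and the source may have more. Where it says the series, first, only, none or still open, it means among the compounds named here.

Compound 1 (`Cc1cc(=O)c2c(OCC3CO3)cc(OCC3CO3)cc2o1`): 6500 nM
Compound 2 (`Cc1cc(=O)c2c(OC[C@@H]3CO3)cc(OC[C@@H]3CO3)cc2o1`): 46100 nM
Compound 3 (`Cc1cc(=O)c2c(OC[C@@H]3CO3)cc(OC[C@H]3CO3)cc2o1`): not yet measured

Compound 1 holds the lower of the two numbers in a functional assay on MCF7 cells (Homo sapiens) for antiproliferative activity, with a stated time of 48 h (a higher number here means a weaker inhibitor, a lower number a stronger inhibitor), and is the stronger inhibitor so far. Compound 3 keeps its atoms and bonds and differs only in drawn configuration (the two compounds have the same atoms and bonds; at least one stereo element is drawn with a configuration in one of them and without one in the other: 2 of 2 stereo elements differ; a stereocentre at a saturated ring carbon is drawn without a configuration in compound 1 and S in compound 3; a stereocentre at a saturated ring carbon is drawn without a configuration in compound 1 and R in compound 3). Among the compounds with values here, the one measured step of this kind, a 7.1-fold higher number from compound 1 to compound 2 (0.85 log units; beyond the scatter), is modest and also defines both stereocentres (the fact that one of compounds 1 and 2 is drawn with a defined configuration and the other without, at the place where they differ). Within the data shown here, a smaller move towards weaker inhibition is expected, since the configuration in compound 3 is not the one in compound 2. The expected change is a 2.2-fold higher number from compound 1 to compound 3 (0.33 log units; beyond the scatter) in this assay and remains uncertain. For compound 3 the estimate is 14000 nM with an expected range from 3500 nM to 46000 nM on this single precedent.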

Compound 3, half-maximal inhibitory concentration: 13900 nM
For compound 3 the middle estimate is 1.0-fold (0.00 log units) above the measured one; the range from low to high includes it.
By their numbers in this assay, from the lowest: compound 1; then compound 3; then compound 2.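

Changing one stereocentre at a saturated ring carbon from S to R gives a 3.3-fold lower number from compound 2 to compound 3 (0.52 log units; beyond the scatter) in this assay, so configuration at a single place is enough to separate these numbers: the fact that compounds 2 and 3 differ only in the configuration as drawn

Drawing one stereocentre S and the other R gives a 2.1-fold higher number from compound 1 to compound 3 (0.33 log units; beyond the scatter), a smaller step than the one seen when both are drawn S.

The compounds shown leave open how the form drawn R at both stereocentres would read, and whether the order would hold with an amine in place of either saturated ring.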